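Chroman amide series: swapping the aryl group on the piperazine

The source may report more compounds than this note shows. Statements on the series, on what has been measured and on what is new or still open speak of the compounds shown alone.

Measured so far:
- compound 1, `Cc1c(C)c2c(c(C)c1O)CCC(C)(C(=O)N1CCN(c3cc(N4CCCC4)nc(N4CCCC4)n3)CC1)O2`: 500 nM
- compound 2, `CC(=O)Oc1c(C)c(C)c2c(c1C)CCC(C)(C(=O)N1CCN(c3cc(N4CCCC4)nc(N4CCCC4)n3)CC1)O2`: 17000 nM
- compound 3, `Cc1c(C)c2c(c(C)c1O)CCC(C)(C(=O)N1CCN(c3ccccn3)CC1)O2`: 1000 nM

All three share the chroman amide core and differ at the phenol oxygen or at the group on the piperazine nitrogen. Among the measured compounds shown here, in a functional assay (brain) for inhibition, with Rattus norvegicus as the target (a higher number here means a weaker inhibitor, a lower number a stronger inhibitor), compound 1 gives 500 nM and compound 2 gives 17000 nM; the only single-point step in the set, a 34-fold higher number from compound 1 to compound 2 (1.53 log units; beyond the scatter), is on the phenol oxygen and is the one large movement seen. Compound 3, with 1000 nM in this assay, stands second highest of the three numbers; its gap to compound 1 is within the scatter, so no order between compound 1 and compound 3 can be read, while its gap to compound 2 is beyond it.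

Compound 4, `COc1ccc(N2CCN(C(=O)C3(C)CCc4c(C)c(O)c(C)c(C)c4O3)CC2)cc1`, has not yet been measured. The change from compound 3 is 4-methoxyphenyl in place of pyridin-2-yl on an amine nitrogen in a ring. For the measured compounds named here, no measured step touches this position; compound 1 and compound 3 carry different groups on the same nitrogen, but their values in this assay lie within the scatter of each other, and the acetylation step does not bear on an aryl swap. The step of a 1.5-fold higher number from compound 3 to compound 4 (0.18 log units; within the scatter) is therefore expected to stay within the scatter. Compound 4 is estimated at 1500 nM, with a range from 500 nM to 5000 nM.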

Compound 4, half-maximal inhibitory concentration: 700 nM
Beside the measured number, compound 4's estimate is 2.1-fold (0.33 log units) above it, within the range that was stated.
By their numbers in this assay, from the lowest: compounds 1, 4 and 3 (each within the scatter of the next); then compound 2.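

In this assay, putting 4-methoxyphenyl in place of pyridin-2-yl on an amine nitrogen in a ring gives a 1.4-fold lower number from compound 3 to compound 4 (0.15 log units; within the scatter) and is the only step at this position among the compounds shown. The two groups cannot be told apart in this read-out, although the entering group has a six-membered aromatic ring of carbon only and more heavy atoms, while the leaving group has a ring with a hetero atom, so this one swap of aromatic rings shows no measurable sensitivity to either difference. No measurement at hand offers an explanation for this result.

On these data alone, whether this position also accepts a group with no aromatic ring, such as cyclohexyl, or a charged substituent on the phenyl ring of compound 4, such as a carboxylic acid or an amine, remains open. Also open, as far as these compounds go, is whether acetyl on the phenol oxygen, which gives a 34-fold higher number from compound 1 to compound 2 (1.53 log units; beyond the scatter) with the aryl group of compound 1, has a step of similar size when 4-methoxyphenyl sits on the amine nitrogen.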